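Swapping benzoyl for acetamido on the triazole-bearing oxime

The compounds below may be only part of what the source reports. "The series", "measured", "known", "first", "only" and "open" are said of these compounds alone.

compound 1 `CCCOc1ccc([C@@H]2CC(=O)c3cc(CC=C(C)C)c(OC)cc3O2)cc1`: 60%
compound 2 `COc1ccc([C@@H]2C/C(=N/OCc3cn(-c4ccc(C(=O)c5ccccc5)cc4)nn3)c3cc(CC=C(C)C)c(OC)cc3O2)cc1`: 41%
compound 3 `CCCCOc1ccc([C@@H]2CC(=O)c3cc(CC=C(C)C)c(OC)cc3O2)cc1`: 57%

In a functional assay on MCF7 cells (Homo sapiens) for inhibition, read by sulforhodamine B assay, with a stated time of 48 h, tested at 50 uM (on this read-out higher numbers stand for more inhibition of growth at the one concentration tested and lower numbers for less inhibition of growth), compound 2 stands lowest of the three at 41%. Compound 3 gives 57% and compound 1 gives 60%. Both gaps to compound 2 lie beyond the scatter. Compound 4 `COc1ccc([C@@H]2C/C(=N/OCc3cn(-c4ccc(NC(C)=O)cc4)nn3)c3cc(CC=C(C)C)c(OC)cc3O2)cc1` carries acetamido in place of benzoyl on an aromatic carbon. Among the compounds with values here, the only measured step is a number 3 percentage points lower from compound 1 to compound 3 (within the scatter). It alters a saturated chain, not the benzoyl group, so no measurement tests this exchange, and no step beyond the scatter is expected in either direction. The estimated step is a number 2 percentage points higher from compound 2 to compound 4 (within the scatter). Compound 4 is expected at 43%, within an estimated range of 25% to 60%.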

Compound 4, percent growth inhibition at one concentration: 0%
The estimate for compound 4 lay 43 percentage points above the measured number; measured number outside the range, below it.
By their numbers in this assay, from the lowest: compound 4; then compound 2; then compounds 3 and 1 (each within the scatter of the next).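

In this assay, acetamido in place of benzoyl gives a number 41 percentage points lower from compound 2 to compound 4 (beyond the scatter), so this aromatic carbon, para to a large group, is sensitive to what it carries, which the earlier step on a saturated chain could not show. The change removes a six-membered aromatic ring of carbon only and adds a hydrogen-bond donor, and these two differences cannot be separated here. Nothing given here accounts for the drop. On these data alone, whether acetyl or an amine at this place would track compound 2 or compound 4 remains open.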